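A Fluorine for a Methoxy Group on the Ring Nitrogen

The source may hold more compounds than are shown below. What is called first, only, known or untested is meant among the compounds shown, and "the series" means these compounds.

Compound 1 `COc1cccc(OC)c1N1C(=O)CSC1c1cccc(C(=O)NCCCCc2ccccc2)c1` gives 41% in a functional assay on U2OS cells (Homo sapiens) for inhibition, read by CCK-8 assay, with a stated time of 72 h, tested at 1 uM (a higher number here means more inhibition at the concentration tested (going by the name of the read-out), a lower number less inhibition), the highest of the three numbers shown. Compound 2 `CCOc1ccccc1N1C(=O)C(C)SC1c1cccc(C(=O)NCCCCc2ccccc2)c1` gives 37% in this assay, a number within the scatter of compound 1. Compound 3 `COc1ccccc1N1C(=O)CSC1C(=O)NCCCCc1ccccc1` gives 6% in this assay, a gap from compound 1 that lies beyond the scatter. Going by the values given here, no pair of measured compounds differs in one place alone. Compound 4 `COc1c(F)cccc1N1C(=O)CSC1c1cccc(C(=O)NCCCCc2ccccc2)c1` differs from compound 1 in one place: 3-fluoro-2-methoxyphenyl in place of 2,6-dimethoxyphenyl on an amide-type nitrogen in a ring. Among the compounds with values here, with no measured step covering this change, a step in this assay of no size beyond the scatter, or a small one downward, is expected. The expected step is a number 6 percentage points lower from compound 1 to compound 4 (within the scatter). Compound 4 is estimated at 35%, in the range 15% to 55%.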

Compound 4, a percentage reported as inhibition, at one concentration (the size of the read-out at that concentration, not a potency): 12%
Compound 4: the middle estimate sits 23 percentage points above what was measured; the measured number lies below the stated range.
By their numbers in this assay, from the lowest: compounds 3 and 4 (each within the scatter of the next); then compounds 2 and 1 (each within the scatter of the next).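

Going by these compounds alone, replacing 2,6-dimethoxyphenyl with 3-fluoro-2-methoxyphenyl on the amide-type ring nitrogen gives a number 29 percentage points lower from compound 1 to compound 4 (beyond the scatter) in this assay, the first comparison here in which only one place changes. It shows that the read-out at this concentration depends on the substituents of this phenyl group, with the rest of compound 1 held constant. Nothing measured here accounts for the drop.

The removal of one methoxy group and the entry of the fluorine occur together in this step, and the compounds shown do not separate them. Going by these compounds, how an amine or a carboxylic acid on this phenyl group would read also remains open.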